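This account rests on a few compounds, and the source may have more. Where it says the series, first, only, none or still open, it means among the compounds named here.

Compound 1 `COc1ccc([C@H]2C[C@@H]2CSc2nc([C@@H](C)c3c(F)cccc3F)c(C)c(=O)[nH]2)cc1`: > 56200 nM
Compound 2 `COc1ccc([C@H]2C[C@@H]2CSc2nc([C@H](C)c3c(F)cccc3F)c(C)c(=O)[nH]2)cc1`: > 56200 nM

In an ADME assay on MT4 cells (Homo sapiens) for cytotoxicity, read by MTT assay (a lower number here means that less compound is tolerated, a higher number that more compound is tolerated), compound 2 gives only a limit, > 56200 nM. Compound 1 also gives only a limit, > 56200 nM. Compound 3 `COc1ccc([C@@H]2C[C@H]2CSc2nc([C@H](C)c3c(F)cccc3F)c(C)c(=O)[nH]2)cc1` departs from compound 2 as follows: the two compounds have the same atoms and bonds and differ only in configuration as drawn: 2 of 3 stereo elements differ; a stereocentre at a saturated ring carbon is drawn S in compound 2 and R in compound 3; a stereocentre at a saturated ring carbon is drawn S in compound 2 and R in compound 3. For the measured compounds named here, the one measured step bearing on this is also purely a change of configuration, at a saturated chain carbon, and it is a step that the two limits leave unreadable from compound 1 to compound 2. It therefore offers no size to carry over, so no step beyond the scatter is expected in this assay, and no direction is favoured. The expected step is a number no higher from compound 2 to compound 3 (the limit leaves the size open). For compound 3, the estimate is 56200 nM, with an expected range of 20000 nM to 100000 nM.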

Compound 3, half-maximal cytotoxic concentration: 14600 nM
Compound 3: the middle estimate sits 3.8-fold (0.59 log units) above what was measured; measured number outside the range, below it.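

In this assay, a change of configuration alone now gives a readable step: inverting both stereocentres at the saturated ring carbons gives an at least 3.8-fold lower number from compound 2 to compound 3 (0.58 log units; beyond the scatter). Inverting all three stereocentres, which yields the mirror image, gives an at least 3.8-fold lower number from compound 1 to compound 3 (0.58 log units; beyond the scatter). The change at the saturated chain carbon remains unreadable, and no atom or bond is involved in the new step: the fact that compounds 2 and 3 differ only in the configuration as drawn

The compounds shown leave open whether one ring carbon alone accounts for the step or both are needed. They also leave open whether the same step appears when the shared core carries an amine or a carboxylic acid.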